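The source may hold more compounds than are shown below. What is called first, only, known or untested is meant among the compounds shown, and "the series" means these compounds.

Compound 1 `CCCCCCCC/C=C\CCCCCCCC(=O)N1CCCC1`: 11.5 ug/mL
Compound 2 `CCCCC/C=C\C/C=C\CCCCCCCC(=O)N1CCCCC1`: 48.9 ug/mL

In a functional assay on OVCAR-3 cells (Homo sapiens) for antiproliferative activity, read by sulforhodamine B assay, with a stated time of 48 h (a lower number here means a stronger inhibitor of growth, a higher number a weaker inhibitor of growth), compound 2 stands at 48.9 ug/mL, the higher of the two numbers, while compound 1 stands at 11.5 ug/mL. That gap lies beyond the usual scatter, so compound 2 is the weaker inhibitor of growth of this pair.

Compound 3 `CCCCCCCC/C=C\CCCCCCCC(=O)N1CCCCC1` has not yet been measured. It differs from compound 2 in one place: heptyl in place of hept-1-en-1-yl on a saturated chain carbon bound to a double-bonded chain carbon. The same difference can also be read as oct-2-en-1-yl to octyl.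

Going by the values given here, no measured pair shows this change on its own, so the data offer no direct guide. The only other measured point is compound 1 at 11.5 ug/mL, which makes a number lower than that of compound 2 a cautious expectation rather than a firm one. In this assay, the expected change is a moderate lowering, an estimated 2.0-fold lower number from compound 2 to compound 3 (0.29 log units; within the scatter). For compound 3 the expected value is 25 ug/mL, with an estimated range from 11 ug/mL to 55 ug/mL.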

Compound 3, concentration for 50% growth inhibition: 9.3 ug/mL
Estimate against measurement, compound 3: 2.7-fold (0.43 log units) above; the measured number lies below the stated range.
By their numbers in this assay, from the lowest: compounds 3 and 1 (each within the scatter of the next); then compound 2.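

In this assay, going by these compounds alone, heptyl in place of hept-1-en-1-yl on a saturated chain carbon bound to a double-bonded chain carbon gives a 5.3-fold lower number from compound 2 to compound 3 (0.72 log units; beyond the scatter), which is beyond the scatter and is the first direct evidence that this part of the chain affects growth inhibition, since the two compounds differ only in the presence of this one extra double bond. The other new comparison concerns the opposite end of the molecule: piperidin-1-yl in place of pyrrolidin-1-yl on a carbonyl carbon gives a 1.2-fold lower number from compound 1 to compound 3 (0.09 log units; within the scatter), which is within the scatter, so this swap shows no measurable effect here. Nothing available explains why the extra double bond goes with weaker growth inhibition.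

These compounds leave open whether the one double bond that remains in compound 3 matters, which a fully saturated chain of the same length would test, and whether a shorter or longer chain would change the number. They also leave open whether the tolerance seen on the carbonyl carbon extends to a morpholin-4-yl group or an open-chain diethylamino group.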